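A hydroxymethyl group added to compound 2

The compounds below may be only part of what the source reports. "The series", "measured", "known", "first", "only" and "open" are said of these compounds alone.

compound 1 `Cc1c(C#N)c(-c2ccc(C#N)cc2)c(C)n1Cc1ccccc1` gives 0.35 ug/mL
compound 2 `Cc1c(C#N)c(-c2ccc(C#N)cc2)c(C)n1Cc1cccnc1` gives 5.1 ug/mL

In a physicochemical assay for solubility, at pH 6.8 (on this read-out higher numbers stand for higher solubility and lower numbers for lower solubility), compound 2 stands at 5.1 ug/mL as the higher of the two numbers. Compound 3 `Cc1c(C#N)c(-c2ccc(C#N)cc2)c(C)n1Cc1cncc(CO)c1` carries hydroxymethyl in place of hydrogen on an aromatic carbon, counted as hydroxymethyl in place of hydrogen on an aromatic carbon against compound 2. Among the measured compounds shown here, the only measured step, a 15-fold higher number from compound 1 to compound 2 (1.16 log units; beyond the scatter) for pyridin-3-yl in place of phenyl, was large and beyond the scatter, but it is a different change and guides only loosely. Expected in this assay is a 1.8-fold higher number from compound 2 to compound 3 (0.25 log units; within the scatter) in the same direction but much smaller. For compound 3 the estimate is 9 ug/mL with an expected range of 3 ug/mL to 30 ug/mL in this measurement.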

Compound 3, solubility: 3.5 ug/mL
For compound 3 the middle estimate is 2.6-fold (0.41 log units) above the measured one, within the range that was stated.
By their numbers in this assay, from the lowest: compound 1; then compounds 3 and 2 (each within the scatter of the next).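

In this assay, hydroxymethyl on this aromatic carbon, two atoms from the ring nitrogen, leaves the read-out within the scatter (a 1.5-fold lower number from compound 2 to compound 3 (0.16 log units; within the scatter)), so this position accepts the added group without a clear change in the number. The 5-(hydroxymethyl)pyridin-3-yl group in place of phenyl still gives a clear step (a 10-fold higher number from compound 1 to compound 3 (1.00 log units; beyond the scatter)). No evidence here bears on the reason for this result. Open, from the compounds shown here alone, is how an amine, a carboxylic acid or a longer chain at this position would read. Also open, going by these compounds, is whether hydroxymethyl would read the same on another carbon of this ring.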